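Sulfur substituent change from compound 2 to compound 3

A few compounds are considered here, and "the series" means these few. Any claim that something is new, unique, unknown or untested is made for them only; others in the source may bear on it.

In a functional assay on SGC-7901 cells (Homo sapiens) for cytotoxicity, read by MTT assay, with a stated time of 48 h (on this read-out higher numbers stand for weaker inhibition and lower numbers for stronger inhibition), compound 1 (`O=C(CSc1ccccc1)N1N=C(c2cc3ccccc3oc2=O)C[C@@H]1c1ccccc1`) gives 20300 nM and compound 2 (`O=C(CSc1ncccn1)N1N=C(c2cc3ccccc3oc2=O)C[C@@H]1c1ccc(C(F)(F)F)cc1`) gives 4390 nM as the lower of the two numbers, a gap beyond the usual scatter. Going by the values given here, these two compounds differ in more than one place, so the series offers no measured step for a single change. Compound 3 (`O=C(CSc1ccc([N+](=O)[O-])cc1)N1N=C(c2cc3ccccc3oc2=O)C[C@@H]1c1ccc(C(F)(F)F)cc1`) carries 4-nitrophenyl in place of pyrimidin-2-yl on a sulfur and otherwise matches compound 2 (4-nitrophenyl in place of pyrimidin-2-yl on a sulfur). Among the compounds with values here, with no measured step to go on, only a small shift is expected in this assay, leaning toward a higher number. The expected change is a 1.4-fold higher number from compound 2 to compound 3 (0.14 log units; within the scatter) and stays within the scatter. The estimate for compound 3 is 6000 nM with 1800 nM to 18000 nM as its expected range.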

Compound 3, half-maximal inhibitory concentration: 8510 nM
Compound 3: middle estimate off by 1.4-fold (0.15 log units), on the low side; measured number inside the range.
By their numbers in this assay, from the lowest: compounds 2 and 3 (each within the scatter of the next); then compound 1.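

The sulfur now has its first single-change step: in this assay, 4-nitrophenyl in place of pyrimidin-2-yl gives a 1.9-fold higher number from compound 2 to compound 3 (0.29 log units; within the scatter). For this pair, then, the number stays within the scatter when a six-membered aromatic ring with 2 hetero atoms gives way to one of carbon only, and when 6 heavy atoms give way to 9, with 2 hydrogen-bond acceptors on each side. No available evidence bears on what lies behind this result.

Going by these compounds, whether this place also accepts a non-aromatic group on the sulfur, such as a cyclohexyl ring or a short chain ending in an amine, remains open. Going by these compounds alone, the separate contribution of the trifluoromethyl group also remains open, as no single-change step isolates it.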